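Swapping an aromatic amide cap for a morpholine amide

The compounds below may be only part of what the source reports. "The series", "measured", "known", "first", "only" and "open" are said of these compounds alone.

Compound 1 `O=C(CCCCCCn1cc(C(=O)NCc2ccc(Cl)cc2)c2ccccc21)NO` and compound 2 `O=C(CCCCCCn1cc(C(=O)Nc2ccc(Cl)cc2Cl)c2ccccc21)NO` share the same core. In an assay on isolated protein for inhibition of protein deacetylase HDAC6 (Homo sapiens), read by fluorescence, with a stated time of 60 min (on this read-out lower numbers stand for stronger inhibition and higher numbers for weaker inhibition), compound 1 gives 1.56 nM, and compound 2 gives 3.73 nM, the higher of the two numbers, with the step of a 2.4-fold higher number from compound 1 to compound 2 (0.38 log units; beyond the scatter). Compound 3 `O=C(CCCCCCn1cc(C(=O)N2CCOCC2)c2ccccc21)NO` differs from compound 2 by morpholin-4-yl in place of (2,4-dichlorophenyl)amino on a carbonyl carbon. Among the compounds with values here, only that one step, which changed the group on the amide nitrogen, bears on this change, and it was modest. A similar modest rise is therefore expected, with the estimated step of a 2.4-fold higher number from compound 2 to compound 3 (0.38 log units; beyond the scatter). Compound 3 is estimated at 9 nM, within a range from 3 nM to 30 nM.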

Compound 3, half-maximal inhibitory concentration: 7.59 nM
Estimate against measurement, compound 3: 1.2-fold (0.07 log units) above; measured number inside the range.
By their numbers in this assay, from the lowest: compound 1; then compound 2; then compound 3.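

Morpholin-4-yl is a non-aromatic ring with no hydrogen-bond donor, yet on the carbonyl carbon it still gives a low number in this assay: a 2.0-fold higher number from compound 2 to compound 3 (0.31 log units; beyond the scatter), and a 4.9-fold higher number from compound 1 to compound 3 (0.69 log units; beyond the scatter). An aromatic ring and an amide hydrogen at this position are therefore not required for strong inhibition, although the number does rise. Nothing available explains that rise.

The ring and the amide hydrogen change together here, so their shares stay unseparated. A piperidin-1-yl group would test what the morpholine oxygen contributes.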